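Cytotoxicity on colon carcinoma cells: chain-end change on compound 1

The source may report more compounds than this note shows. Statements on the series, on what has been measured and on what is new or still open speak of the compounds shown alone.

Measured compounds:
compound 1, `c1coc(CNc2nc(NCCCN3CCCC3)nc3ccccc23)c1`, 87.5%
compound 2, `Cc1cccc(N2CCN(CCCCNc3nc(NCc4ccco4)c4cc(F)ccc4n3)CC2)c1C`, 96.1%
compound 3, `Clc1cccc(N2CCN(CCCNc3nc(NCc4ccco4)c4ccccc4n3)CC2)c1Cl`, 94.1%

In a functional assay on HT-29 cells (Homo sapiens) for cytotoxicity, read by MTT assay, with a stated time of 2 days, tested at 10 uM (on this read-out higher numbers stand for more inhibition at the one concentration tested (going by the name of the read-out) and lower numbers for less inhibition), compound 1 gives 87.5%. Compound 2 gives 96.1% and compound 3 gives 94.1% in this assay; the gaps from compound 1 to either are within the usual scatter, so none of the three stands apart from the others. Within the data shown here, no two measured compounds differ in one place only, so no single step can be anchored from these numbers.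

Compound 4, `CCCCNc1nc(NCc2ccco2)c2ccccc2n1`, is the unmeasured member. Relative to compound 1 the change is methyl in place of pyrrolidin-1-yl on a saturated chain carbon, three bonds along the chain from a nitrogen on an aromatic ring. Among the measured compounds shown here, every measured compound carries a ring on the chain end; compound 4 carries none, so the step has no measured counterpart.

For compound 4 the expected value in this assay is 45%, with a range from 15% to 80%. This estimate means a step of a number 42.5 percentage points lower from compound 1 to compound 4 (beyond the scatter), expected to be a decrease beyond the scatter.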

Compound 4, a percentage reported as inhibition, at one concentration (the size of the read-out at that concentration, not a potency): 92.3%
Beside the measured number, compound 4's estimate is 47.3 percentage points below it, outside the stated range (above it).
By their numbers in this assay, from the lowest: compounds 1, 4, 3 and 2 (each within the scatter of the next).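

In this assay, methyl in place of pyrrolidin-1-yl on a saturated chain carbon, three bonds along the chain from a nitrogen on an aromatic ring, gives a number 4.8 percentage points higher from compound 1 to compound 4 (within the scatter). This pair shows that, on the core of compound 1, butyl can stand in place of 3-(pyrrolidin-1-yl)propyl with no change in this read-out beyond the scatter, so a ring on the chain end is not required for the inhibition seen at the one concentration tested. Nothing available bears on why this change leaves the read-out within the scatter.

Open, as far as these compounds go, is whether a chain ending in a carboxylic acid or a hydroxyl group, or a shorter chain such as ethyl, would read alike on this core. A single concentration also leaves open whether compound 1 and compound 4 would separate across a range of concentrations.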